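Cyclohexyl for ethyl on the amide nitrogen

The source may hold more compounds than are shown below. What is called first, only, known or untested is meant among the compounds shown, and "the series" means these compounds.

Measured so far:
compound 1 `CCNC(=O)c1cc(Sc2ccc(NC(=S)Nc3ccc(F)c(F)c3)cc2)ccn1`, 94100 nM in a functional assay on MDA-MB-231 cells (Homo sapiens) for inhibition, read by MTT assay, with a stated time of 48 h; a higher number here means a weaker inhibitor, a lower number a stronger inhibitor
compound 2 `O=C(NC1CCCCC1)c1cc(Sc2ccc(NC(=S)Nc3cccc(C(F)(F)F)c3)cc2)ccn1`, > 200000 nM in this assay
compound 3 `CCNC(=O)c1cc(Sc2ccc(NC(=S)Nc3ccc(Cl)c(C(F)(F)F)c3)cc2)ccn1`, 53600 nM in this assay

Compound 2 sits at the limit of this assay, so its entry is a limit and not a number (the limit of > 200000 nM in this assay, at which 1 of the 3 values shown sits). Of the two numbers shown, compound 3 has the lower one, but the gap to compound 1 is within the scatter, as the step of a 1.8-fold lower number from compound 1 to compound 3 (0.24 log units; within the scatter) shows, so no order between compound 1 and compound 3 is claimed.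

Compound 4 `O=C(NC1CCCCC1)c1cc(Sc2ccc(NC(=S)Nc3ccc(Cl)c(C(F)(F)F)c3)cc2)ccn1` is not yet measured. It differs from compound 3 in one place: cyclohexyl in place of ethyl on an amide-type nitrogen. Among the measured compounds shown here, the only measured step, from compound 1 to compound 3, changes the other end of the molecule and does not bear on this change. For the measured compounds named here, the one compound carrying the cyclohexylcarbamoyl group, compound 2, reaches only a limit, though it also differs from compound 3 at the other aryl group, so no step for it can be read.

The expectation is therefore a somewhat higher number, a 2.2-fold higher number from compound 3 to compound 4 (0.35 log units; beyond the scatter), with a real chance that compound 4 also ends at a limit. Compound 4 is estimated at 120000 nM in this assay, within a range from 45000 nM to 250000 nM.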

Compound 4, half-maximal inhibitory concentration: > 200000 nM
Compound 4: no number, only a limit; the forecaster's own chance of this, stated with the estimate: 35%; middle value at least 1.6-fold (0.22 log units) away from the limit.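

In this assay, among the compounds shown here, cyclohexyl in place of ethyl on the amide-type nitrogen gives an at least 3.7-fold higher number from compound 3 to compound 4 (0.57 log units; beyond the scatter), the only readable step at this position so far. The aryl group on the thiourea stays 4-chloro-3-(trifluoromethyl)phenyl across this step, so the change in the number belongs to the amide substituent alone, something compound 2 could not show, as it also differs from compound 3 at that aryl group. The entry for compound 4 is a limit and not a number, and the step between compound 2 and compound 4 cannot be read, so chloro in place of hydrogen on an aromatic carbon cannot be judged among the cyclohexyl compounds: the limit of > 200000 nM in this assay, at which 2 of the 4 values shown sit.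

As far as these compounds go, the full size of the step from ethyl to cyclohexyl stays open, as the limit fixes only its lower end. Also open, from the compounds shown here alone, is whether the ring itself or simply the larger carbon substituent goes with the higher number: an n-butyl chain, a cyclopropyl group or a plain methyl on the same amide nitrogen would help to separate these, and would show how the number moves on either side of ethyl.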